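Hydroxy-to-carboxy exchange on two related cores

A few compounds are considered here, and "the series" means these few. Any claim that something is new, unique, unknown or untested is made for them only; others in the source may bear on it.

Measured so far in a functional assay on A-375 cells (Homo sapiens) for antiproliferative activity, read by MTT assay, with a stated time of 24 h, tested at 33.33 ug/mL; a lower number here means a weaker effect, a higher number a stronger effect of the compound at the concentration tested:
- compound 1, `Cc1c(C(=O)Nc2c(F)cc(-c3cccc(F)c3)cc2F)nc2ccc(C(F)(F)F)cc2c1O`, gives 61.3%
- compound 2, `COc1ccc2nc(C(=O)Nc3ccc(-c4ccccc4)cc3)c(C)c(O)c2c1`, gives 46.3%
- compound 3, `Cc1c(C(=O)Nc2c(F)cc(-c3cccc(F)c3)cc2F)nc2ccc(C(F)(F)F)cc2c1C(=O)O`, gives 51%

Compound 1 and compound 3 share one core; compound 2 carries a second core, and the difference between the two cores is not broken down here. Within the first core the change carboxy in place of hydroxy on an aromatic carbon produces a number 10.3 percentage points lower from compound 1 to compound 3 (beyond the scatter) in this assay, a modest drop that lies beyond the scatter. Compound 2 stands within the scatter of compound 3 but beyond it relative to compound 1, as the values show.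

Compound 4, `COc1ccc2nc(C(=O)Nc3ccc(-c4ccccc4)cc3)c(C)c(C(=O)O)c2c1`, remains to be measured. It arises from compound 2 by carboxy in place of hydroxy on an aromatic carbon, the same change already seen once on the first core. With only one earlier occurrence, the expectation rests on that single step alone. For compound 4 a step of a number 9.3 percentage points lower from compound 2 to compound 4 (within the scatter) is expected in this assay, due to a number 10.3 percentage points lower from compound 1 to compound 3 (beyond the scatter) observed for compound 1 and compound 3. Compound 4 is therefore estimated at 37%, with a likely range from 25% to 50%.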

Compound 4, a percentage reported as inhibition, at one concentration (the size of the read-out at that concentration, not a potency): 58.3%
Estimate against measurement, compound 4: 21.3 percentage points below; the measured number lies above the stated range.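

On the core of compound 2, carboxy in place of hydroxy on an aromatic carbon gives a number 12 percentage points higher from compound 2 to compound 4 (beyond the scatter) in this assay, so the step reverses direction relative to the one on the core of compound 1. In this series, the result of the exchange therefore does not transfer from one core to the other, and a step measured on one core is a poor guide to the other: the same change on two cores in this assay, a number 10.3 percentage points lower (beyond the scatter) from compound 1 to compound 3 and a number 12 percentage points higher (beyond the scatter) from compound 2 to compound 4, 22.3 percentage points apart, beyond the scatter of two such steps. For the compounds shown here, the two pairs show that the outcome depends on the core, but not which of the several differences between the cores matters, nor whether the reversal would hold at other concentrations, as each read-out comes from a single concentration and each core provides only one pair.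

Going by these compounds, it remains open whether the methoxy or trifluoromethyl group on the fused ring system, or the fluoro groups on the biaryl amide part, govern the direction of the step. Also open, on these data alone, is how an amine or a primary amide on that same aromatic carbon would compare with hydroxy and carboxy on each core.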